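The source may report more compounds than this note shows. Statements on the series, on what has been measured and on what is new or still open speak of the compounds shown alone.

Measured in a functional assay on A549 cells (Homo sapiens) for inhibition, read by MTT assay, with a stated time of 48 h; a higher number here means a weaker inhibitor, a lower number a stronger inhibitor:
- compound 1 `Cn1c(/C=C2\SC(=O)N(CC(=O)Nc3cc(C(C)(C)C)on3)C2=O)nc2ccccc21`: 15300 nM
- compound 2 `CC(C)n1c(/C=C2\SC(=O)N(CC(=O)N3CCCCC3)C2=O)nc2ccccc21`: 28200 nM
- compound 3 `Cn1c(/C=C2\SC(=O)N(CC(=O)N3CCCCC3)C2=O)nc2ccccc21`: > 50000 nM (a limit of the assay, not a number)

Compound 2 and compound 1 give numbers that lie within the usual scatter of each other, so no order between them is claimed. Compound 3 sits at the assay limit of > 50000 nM in this assay, at which 1 of the 3 values shown sits, and contributes no number.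

Compound 4 `CC(C)n1c(/C=C2\SC(=O)N(CC(=O)Nc3cc(C(C)(C)C)on3)C2=O)nc2ccccc21` is not yet measured. Relative to compound 2 the change is (5-(tert-butyl)-1,2-oxazol-3-yl)amino in place of piperidin-1-yl on a carbonyl carbon. Within the data shown here, only one measured step in this assay bears on that change directly: in the methyl series an at least 3.2-fold higher number from compound 1 to compound 3 (0.51 log units; beyond the scatter), which runs in the opposite direction to the step now followed. The other shown step, an at least 1.7-fold higher number from compound 2 to compound 3 (0.24 log units; that floor lies within the scatter), concerns the substituent on the aromatic nitrogen, which is held as isopropyl in both compound 2 and compound 4, and is anyway a floor within the scatter.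

Reversing the direction of the measured step, compound 4 is expected to give a lower number than compound 2 in this assay, by a modest margin: a 3.1-fold lower number from compound 2 to compound 4 (0.50 log units; beyond the scatter). The estimate for compound 4 is therefore 9000 nM, with a range from 3000 nM to 30000 nM.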

Compound 4, half-maximal inhibitory concentration: > 50000 nM
Compound 4: a limit, no number (the forecaster's own chance of this, stated with the estimate: 5%); middle value at least 5.5-fold (0.74 log units) from the limit.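

In this assay, (5-(tert-butyl)-1,2-oxazol-3-yl)amino in place of piperidin-1-yl on the carbonyl carbon does not carry over from the methyl compounds to the isopropyl compounds, so the outcome of this change depends on the group on the aromatic nitrogen: the same change on two cores in this assay, an at least 3.2-fold higher number (0.51 log units; beyond the scatter) from compound 1 to compound 3 and an at least 1.7-fold lower number (0.24 log units; that floor lies within the scatter) from compound 4 to compound 2, at least 5.7-fold (0.76 log units) apart, beyond the scatter of two such steps

The same dependence appears from the other side, where isopropyl in place of methyl on the aromatic nitrogen gives an at least 3.2-fold higher number from compound 1 to compound 4 (0.51 log units; beyond the scatter), and this step does not match the one seen with piperidin-1-yl on the carbonyl carbon: the same change on two cores in this assay, an at least 1.7-fold higher number (0.24 log units; that floor lies within the scatter) from compound 2 to compound 3 and an at least 3.2-fold lower number (0.51 log units; beyond the scatter) from compound 4 to compound 1, at least 5.7-fold (0.76 log units) apart, beyond the scatter of two such steps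

The change on the isopropyl core gives an at least 1.7-fold higher number from compound 2 to compound 4 (0.24 log units; that floor lies within the scatter), and its full size stays unfixed since the entry for compound 4 is a limit and not a number: the limit of > 50000 nM in this assay, at which 2 of the 4 values shown sit.

The compounds shown leave open how far compound 4 lies from compound 2, and whether the dependence holds for other groups on the aromatic nitrogen, such as ethyl or cyclopropyl. They also leave open whether a morpholin-4-yl group on the carbonyl carbon would behave like piperidin-1-yl on the methyl and isopropyl cores.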